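Hydroxy in Place of Chloro on the Anilino Ring

The source may report more compounds than this note shows. Statements on the series, on what has been measured and on what is new or still open speak of the compounds shown alone.

Compound 3 `COc1ccc(-c2nn(-c3ccccc3)cc2C(=O)/C=C\Nc2ccc(Cl)cc2)cc1` gives 8860 nM in a functional assay on U-87MG ATCC cells (Homo sapiens) for antiproliferative activity, read by MTT assay, with a stated time of 48 h; on this read-out lower numbers stand for stronger inhibition and higher numbers for weaker inhibition. Among the three measured compounds it stands second highest; compound 2 `COc1ccc(-c2nn(-c3ccccc3)cc2C(=O)/C=C\Nc2ccc(F)cc2)cc1` gives 8910 nM, and compound 1 `O=C(/C=C\Nc1ccc(O)cc1)c1cn(-c2ccccc2)nc1-c1ccc(F)cc1` gives 4700 nM, both within the scatter of compound 3. Compound 4 `COc1ccc(-c2nn(-c3ccccc3)cc2C(=O)/C=C\Nc2ccc(O)cc2)cc1` differs from compound 3 by hydroxy in place of chloro on an aromatic carbon. For the measured compounds named here, the only single-point step measured, a 1.0-fold lower number from compound 2 to compound 3 (0.00 log units; within the scatter), lies within the scatter. Going by the values given here, no measured step swaps a halogen for hydroxy on this ring; compound 1, which carries the same hydroxy but differs elsewhere as well, gives a number within the scatter of compound 3. For compound 4 the expected step is therefore a 1.4-fold lower number from compound 3 to compound 4 (0.13 log units; within the scatter), within the scatter. Compound 4 is expected to give 6500 nM, estimated between 2800 nM and 15000 nM.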

Compound 4, half-maximal inhibitory concentration: 3730 nM
Compound 4: middle estimate off by 1.7-fold (0.24 log units), on the high side, and the stated range covers the measured number.
By their numbers in this assay, from the lowest: compounds 4, 1, 3 and 2 (each within the scatter of the next, the first and the last beyond it).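

In this assay, for the compounds shown here, a change on this ring moves the number beyond the scatter for the first time: hydroxy in place of chloro gives (a 2.4-fold lower number from compound 3 to compound 4 (0.38 log units; beyond the scatter)) and hydroxy in place of fluoro gives (a 2.4-fold lower number from compound 2 to compound 4 (0.38 log units; beyond the scatter)). With hydroxy on this ring, methoxy in place of fluoro at the other aromatic site gives (a 1.3-fold lower number from compound 1 to compound 4 (0.10 log units; within the scatter)). Nothing available accounts for the shift seen with hydroxy. Going by these compounds, whether an amine or a carboxylic acid at this place would give a lower number stays open.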